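Repositioning a Hydroxyl on a Weakly Cytotoxic Series

This account rests on a few compounds, and the source may have more. Where it says the series, first, only, none or still open, it means among the compounds named here.

Compound 2 `Oc1ccc(-c2cc(-c3ccncc3)nc(-c3ccc(Cl)cc3)c2)cc1` carries a 4-hydroxyphenyl group on the shared core; in a functional assay on T47D cells (Homo sapiens) for cytotoxicity, read by CCK-8 assay and cell counting, with a stated time of 2 days (on this read-out lower numbers stand for stronger inhibition and higher numbers for weaker inhibition), compound 2 has "not determined" (no result reported), so its standing cannot be read from a number. Its neighbours give some orientation: compound 1 `Oc1cccc(-c2cc(-c3ccc(Cl)cc3)nc(-c3ccco3)c2)c1` shows 10500 nM in this assay, and compound 3 `Oc1ccc(-c2cc(-c3ccc(Cl)cc3)nc(-c3ccccn3)c2)cc1` shows 25900 nM in this assay, both weak inhibitors. Compound 4 `Oc1cccc(-c2cc(-c3ccncc3)nc(-c3ccc(Cl)cc3)c2)c1` differs from compound 2 only in one place: 3-hydroxyphenyl in place of 4-hydroxyphenyl on an aromatic carbon. Going by the values given here, with no measured step for this change, the expectation is that compound 4 stays within the weakly inhibiting range that compounds 1 and 3 occupy in this assay, with no clear direction beyond the scatter. Compound 4 is therefore estimated at 15000 nM, between 5000 nM and 50000 nM.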

Compound 4, half-maximal inhibitory concentration: 3330 nM
Beside the measured number, compound 4's estimate is 4.5-fold (0.65 log units) above it; measured number below the stated range.
By their numbers in this assay, from the lowest: compound 4; then compound 1; then compound 3.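

With 3-hydroxyphenyl kept in both compounds, pyridin-4-yl in place of furan-2-yl on an aromatic carbon gives, in this assay, a 3.2-fold lower number from compound 1 to compound 4 (0.50 log units; beyond the scatter). Going by these compounds alone, this is the first readable sign that the group at this other site of the shared core changes the read-out. The move from 4-hydroxyphenyl to 3-hydroxyphenyl cannot be read, as compound 2 has no number. Nothing measured here explains the step. Open, going by these compounds, is whether an amine or a methoxy group in place of the hydroxyl would keep the number of compound 4 in this assay.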